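Chloro to hydrogen on the pendant phenyl of compound 1

The source may report more compounds than this note shows. Statements on the series, on what has been measured and on what is new or still open speak of the compounds shown alone.

Measured so far in a functional assay on UO-31 cells (Homo sapiens) for inhibition; a higher number here means a weaker inhibitor of growth, a lower number a stronger inhibitor of growth:
- compound 1, `COc1cc(/C=C/C(=O)c2cccc(-n3cc(-c4ccc(Cl)cc4)[nH]c3=O)c2)cc(OC)c1OC`: 7030 nM
- compound 2, `COc1cc(/C=C/C(=O)c2cccc(-n3cc(-c4ccccc4)[nH]c3=O)c2)ccc1O`: 2180 nM
- compound 3, `O=C(/C=C/c1cccc(O)c1)c1cccc(-n2cc(-c3ccccc3)[nH]c2=O)c1`: 2160 nM

Compound 1 has the highest of the three numbers; compound 2 and compound 3 sit together well beyond the scatter from it. Among the measured compounds shown here, the only single-point step among the measured set, a 1.0-fold lower number from compound 2 to compound 3 (0.00 log units; within the scatter), shows that exchanging the hydroxyphenyl pattern on the chain leaves this assay unchanged.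

Compound 4, `COc1cc(/C=C/C(=O)c2cccc(-n3cc(-c4ccccc4)[nH]c3=O)c2)cc(OC)c1OC`, is compound 1 with hydrogen in place of chloro on an aromatic carbon. For the measured compounds named here, no measured pair isolates this exchange. Compound 2 and compound 3 carry the unsubstituted phenyl, but each also differs from compound 1 in the aryl on the double-bonded chain, so the gap between compound 1 and compound 2 cannot be split between the two changes. The step from compound 2 to compound 3 suggests the chain aryl contributes little, which would leave the chloro-to-hydrogen change as the likelier source of that gap, though this rests on one comparison.

For compound 4 a move toward the phenyl compounds is therefore expected, a 2.0-fold lower number from compound 1 to compound 4 (0.30 log units; within the scatter), with considerable uncertainty. The estimate for compound 4 is 3500 nM, within 1400 nM to 9000 nM.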

Compound 4, concentration for 50% growth inhibition: 1510 nM
Beside the measured number, compound 4's estimate is 2.3-fold (0.37 log units) above it, and the stated range covers the measured number.
By their numbers in this assay, from the lowest: compounds 4, 3 and 2 (each within the scatter of the next); then compound 1.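

In this assay, among the compounds shown here, the pair gives the first clean reading of this exchange, with a 4.7-fold lower number from compound 1 to compound 4 (0.67 log units; beyond the scatter) and the rest of the structure held fixed. Para to a large group on the pendant ring, chloro and hydrogen are therefore separable in this read-out, with the lower number belonging to the phenyl compound. With phenyl in place, compounds 4, 3 and 2 stand each within the scatter of the next, so among these three the aryl on the chain does not separate the numbers, and compound 1 stands apart from them. No data in hand give a reason for the step.

The compounds shown compare only chloro and hydrogen at this position, so what fluoro, methoxy or an amine would give there remains open. As far as these compounds go, the step is also read only with the aryl shared by compound 1 and compound 4, so its size with 3-hydroxyphenyl or 4-hydroxy-3-methoxyphenyl on the chain remains open too.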